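From Pyrrolidin-1-yl to Triazol-1-yl: An Expected Loss

This account rests on a few compounds, and the source may have more. Where it says the series, first, only, none or still open, it means among the compounds named here.

In a functional assay on HCT-116 cells (Homo sapiens) for cytotoxicity, read by MTT assay, with a stated time of 72 h (a lower number here means a stronger inhibitor, a higher number a weaker inhibitor), compound 1 `COc1ncc(-c2ccc3nccc(-c4ccc(C)cc4)c3c2)cc1NS(=O)(=O)c1ccc(F)cc1F` gives 2540 nM. Compound 2 `CCN(CC)Cc1ccc(-c2ccnc3ccc(-c4cnc(OC)c(NS(=O)(=O)c5ccc(F)cc5F)c4)cc23)cc1` gives 5 nM, and compound 3 `COc1ncc(-c2ccc3nccc(-c4ccc(CN5CCCC5)cc4)c3c2)cc1NS(=O)(=O)c1ccc(F)cc1F` gives 18.8 nM, standing second of the three measured: a 3.8-fold higher number from compound 2 to compound 3 (0.58 log units; beyond the scatter), while a 140-fold lower number from compound 1 to compound 3 (2.13 log units; beyond the scatter). Both large gains, a 510-fold lower number from compound 1 to compound 2 (2.71 log units; beyond the scatter) and a 140-fold lower number from compound 1 to compound 3 (2.13 log units; beyond the scatter), came from putting diethylamino or pyrrolidin-1-yl on that saturated chain carbon bound to an aromatic carbon. Compound 4 `COc1ncc(-c2ccc3nccc(-c4ccc(Cn5cncn5)cc4)c3c2)cc1NS(=O)(=O)c1ccc(F)cc1F` differs from compound 3 by 1H-1,2,4-triazol-1-yl in place of pyrrolidin-1-yl on a saturated chain carbon bound to an aromatic carbon. Among the compounds with values here, this removes the group that carried the gain and installs a ring of a different kind, for which no measured step exists, so the outcome is uncertain, but a loss is expected. For compound 4 the estimate is 300 nM, with a range of 50 nM to 2500 nM, an expected 16-fold higher number from compound 3 to compound 4 (1.20 log units; beyond the scatter).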

Compound 4, half-maximal inhibitory concentration: 8.7 nM
The estimate for compound 4 lay 34-fold (1.54 log units) above the measured number; the measured number lies below the stated range.
By their numbers in this assay, from the lowest: compounds 2 and 4 (each within the scatter of the next); then compound 3; then compound 1.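

At this position, on a saturated chain carbon bound to an aromatic carbon, an aromatic ring does as well as the non-aromatic groups: 1H-1,2,4-triazol-1-yl in place of pyrrolidin-1-yl gives a modest step (a 2.2-fold lower number from compound 3 to compound 4 (0.33 log units; beyond the scatter)), and in place of diethylamino gives a step within the scatter (a 1.7-fold higher number from compound 2 to compound 4 (0.24 log units; within the scatter)). The large gain over hydrogen therefore survives (a 290-fold lower number from compound 1 to compound 4 (2.47 log units; beyond the scatter)), so it does not require either of those two groups. Nothing measured here explains this result.

From the compounds shown here alone, whether the triazole's three nitrogens each matter remains open. So does how an imidazol-1-yl ring, a morpholin-4-yl ring or a carboxylic acid would behave on that carbon.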